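One Aryl Swap and What Vero Cells Tolerate

This account rests on a few compounds, and the source may have more. Where it says the series, first, only, none or still open, it means among the compounds named here.

Of the compounds shown here, three have been tested in an ADME assay on Vero 76 cells (Chlorocebus sabaeus) for cytotoxicity, read by crystal violet staining, with a stated time of 96 h; a higher number here means that more compound is tolerated, a lower number that less compound is tolerated. Compound 1 `FC(F)(F)c1cccc(NC(=S)Nc2ccc(I)cc2)c1` gives 9500 nM, the lowest of the three numbers, so it is the least tolerated of the set. Compound 2 `Cc1ccc(NC(=S)Nc2cccc(C(F)(F)F)c2)cc1Cl` gives 20000 nM, and compound 3 `CCOC(=O)c1ccc(NC(=S)Nc2cccc(C(F)(F)F)c2)cc1` gives 71000 nM, the highest. Within the data shown here, the only single-point step among them runs a 7.5-fold higher number from compound 1 to compound 3 (0.87 log units; beyond the scatter), and it concerns a different part of the molecule from the change considered here.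

Compound 4 `FC(F)(F)c1cccc(NC(=S)Nc2ccccc2Br)c1` differs from compound 1 in one place: 2-bromophenyl in place of 4-iodophenyl on an amide-type nitrogen. Among the measured compounds shown here, no measured pair tests this kind of swap, one halogen-bearing ring for another. For the measured compounds named here, the single step on record, from compound 1 to compound 3, shows that changing a group on that ring can move this assay modestly, so a step of similar or smaller size, in either direction, would be unsurprising for compound 4, with a slightly higher number the more likely outcome. Compound 4 is therefore expected to give about 15000 nM, with a likely range from 5000 nM to 45000 nM. This estimate corresponds to a step of a 1.6-fold higher number from compound 1 to compound 4 (0.20 log units; within the scatter).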

Compound 4, half-maximal cytotoxic concentration: 50000 nM
Compound 4: the middle estimate sits 3.3-fold (0.52 log units) below what was measured, outside the stated range (above it).
By their numbers in this assay, from the lowest: compound 1; then compound 2; then compounds 4 and 3 (each within the scatter of the next).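

In this assay, placing 2-bromophenyl where 4-iodophenyl stood on the amide-type nitrogen gives a 5.3-fold higher number from compound 1 to compound 4 (0.72 log units; beyond the scatter), so the number can rise while the ring still carries a halogen, something the earlier swap of iodo for ethoxycarbonyl could not show. The two groups have the same counts of heavy atoms, hydrogen-bond donors and acceptors, and the same lack of net charge, so those counts do not separate them, yet the assay does. The swap changes the halogen and its place on the ring together, so the step belongs to the two changes taken as one.

Nothing available here explains the rise. The compounds shown leave open which change matters more, a question that 4-bromophenyl or 2-iodophenyl on the same nitrogen would address, and how a ring bearing an amine would behave.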